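Series notes: swapping one aryl group on the shared core

The compounds below may be only part of what the source reports. "The series", "measured", "known", "first", "only" and "open" are said of these compounds alone.

Measured in a functional assay on SW-620 cells (Homo sapiens) for cytotoxicity, read by MTT assay, with a stated time of 72 h; a lower number here means a stronger inhibitor, a higher number a weaker inhibitor:
compound 1 `COc1ccc(/C=C2\CCC/C(=C\c3cccc(Cl)c3)C2=O)cc1OC`: 5100 nM
compound 2 `COc1ccccc1/C=C1\CCC/C(=C\c2ccc(OC)c(OC)c2)C1=O`: 7800 nM

Of the two numbers, compound 2 carries the higher one, yet the gap is only a 1.5-fold higher number from compound 1 to compound 2 (0.18 log units; within the scatter), within the scatter. Compound 3 `COc1ccc(/C=C2\CCC/C(=C\c3cccc(O)c3)C2=O)cc1OC` differs from compound 2 by 3-hydroxyphenyl in place of 2-methoxyphenyl on a double-bonded chain carbon bound to a double-bonded ring carbon. Within the data shown here, the single step bearing on a change at this place, a 1.5-fold higher number from compound 1 to compound 2 (0.18 log units; within the scatter), stayed within the scatter, so an aryl swap here has so far been neutral. No movement beyond the scatter is expected for a 1.3-fold lower number from compound 2 to compound 3 (0.11 log units; within the scatter). Compound 3 is estimated at 6000 nM, expected to fall between 2500 nM and 15000 nM.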

Compound 3, half-maximal inhibitory concentration: 1900 nM
Estimate against measurement, compound 3: 3.2-fold (0.50 log units) above, outside the stated range (below it).
By their numbers in this assay, from the lowest: compound 3; then compounds 1 and 2 (each within the scatter of the next).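

The aryl group on a double-bonded chain carbon bound to a double-bonded ring carbon is not neutral in this assay after all: 3-hydroxyphenyl in place of 2-methoxyphenyl gives a 4.1-fold lower number from compound 2 to compound 3 (0.61 log units; beyond the scatter). Hydroxy in place of chloro on an aromatic carbon also gives a 2.7-fold lower number from compound 1 to compound 3 (0.43 log units; beyond the scatter), so both steps to the hydroxy compound pass the scatter, although both are modest. No data accompany these compounds to account for the shift. From the compounds shown here alone, whether an amine or a carboxylic acid on that aromatic carbon would keep the lower number stays open.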